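Replacing the Ethynyl Group by Iodine in Compound 3

A few compounds are considered here, and "the series" means these few. Any claim that something is new, unique, unknown or untested is made for them only; others in the source may bear on it.

Measured so far:
- compound 1 `COc1ncnc2c1c(-c1ccsc1)cn2[C@@H]1O[C@H](CO)[C@@H](O)[C@H]1O`: 430 nM
- compound 2 `C#Cc1cn([C@@H]2O[C@H](CO)[C@@H](O)[C@H]2O)c2ncnc(OC)c12`: 12700 nM

In a functional assay on HepG2 cells (Homo sapiens) for antiproliferative activity, read by XTT assay, with a stated time of 72 h (on this read-out higher numbers stand for weaker inhibition and lower numbers for stronger inhibition), compound 2 gives the highest of the two numbers; its nearest neighbour is compound 1, and the step of a 30-fold higher number from compound 1 to compound 2 (1.47 log units; beyond the scatter) is large. Compound 3 `COc1ncnc2c1c(I)cn2[C@@H]1O[C@H](CO)[C@@H](O)[C@H]1O` is not yet measured. It differs from compound 2 by iodo in place of ethynyl on an aromatic carbon. Within the data shown here, no measured step involves an iodo group, so the only guide is that the large aryl group of compound 1 gave a much stronger number than the small ethynyl of compound 2. Iodo is likewise a small group, so compound 3 is expected to stay nearer compound 2 than compound 1, with a modest change, a 2.1-fold lower number from compound 2 to compound 3 (0.33 log units; beyond the scatter), in this assay. Compound 3 is thus estimated at 6000 nM, with a range from 1200 nM to 30000 nM.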

Compound 3, half-maximal inhibitory concentration: > 20000 nM
Compound 3 gave a limit, no number; the forecaster's own chance of this, stated with the estimate: 15%; middle value at least 3.3-fold (0.52 log units) from the limit.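

In this assay compound 3 gives only a limit of the assay, not a number: the limit of > 20000 nM in this assay, at which 1 of the 3 values shown sits.

Replacing thiophen-3-yl with iodo on this aromatic carbon of the five-membered aromatic ring gives an at least 46-fold higher number from compound 1 to compound 3 (1.66 log units; beyond the scatter) and this is a large step. Compound 1 therefore stands apart from two replacements, ethynyl and iodo, rather than from ethynyl alone. Iodo in place of ethynyl gives an at least 1.5-fold higher number from compound 2 to compound 3 (0.19 log units; that floor lies within the scatter) but that floor lies within the scatter, so these compounds do not show that the two groups differ.

Going by these compounds, it remains open how far the true value of compound 3 lies beyond its limit. On these data alone, it is also open whether an amine, a longer chain or a phenyl group on this carbon would come closer to compound 1 or stay with compound 2 and compound 3.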